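A few compounds are considered here, and "the series" means these few. Any claim that something is new, unique, unknown or untested is made for them only; others in the source may bear on it.

Measured so far:
compound 1, `C=C(Br)C(=O)Nc1ccc2c(c1)/C(=C\c1ccc(C)s1)C(=O)N2`: 12 nM
compound 2, `C=C(Br)C(=O)Nc1ccc2c(c1)/C(=C\c1ccsc1)C(=O)N2`: 770 nM
compound 3, `C=C(Br)C(=O)Nc1ccc2c(c1)/C(=C/c1ccsc1)C(=O)N2`: 350 nM

All three were tested in a functional assay on HL-60 cells (Homo sapiens) for antiproliferative activity, read by MTT assay, with a stated time of 72 h; a lower number here means a stronger inhibitor, a higher number a weaker inhibitor. Compound 2 and compound 3 share every atom and bond: the two compounds have the same atoms and bonds and differ only in configuration as drawn: 1 of 1 stereo elements differ; a double bond is drawn E in compound 2 and Z in compound 3. That difference alone gave a 2.2-fold lower number from compound 2 to compound 3 (0.34 log units; beyond the scatter), which rests on (the fact that compounds 2 and 3 differ only in the configuration as drawn). Compound 1 differs from compound 2 by 5-methylthiophen-2-yl in place of thiophen-3-yl on a double-bonded chain carbon bound to a double-bonded ring carbon, and this change gave a 64-fold lower number from compound 2 to compound 1 (1.81 log units; beyond the scatter). Compound 4, `C=C(Br)C(=O)Nc1ccc2c(c1)/C(=C/c1ccc(C)s1)C(=O)N2`, is not yet measured. It differs from compound 3 by 5-methylthiophen-2-yl in place of thiophen-3-yl on a double-bonded chain carbon bound to a double-bonded ring carbon, the same change at the same place as from compound 2 to compound 1. Compound 4 is expected to show a step of a 44-fold lower number from compound 3 to compound 4 (1.64 log units; beyond the scatter), which rests on a 64-fold lower number from compound 2 to compound 1 (1.81 log units; beyond the scatter) applied to the value of compound 3, 350 nM. Compound 4 is therefore estimated at 8 nM, with a likely range from 2 nM to 35 nM.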

Compound 4, half-maximal inhibitory concentration: 24 nM
Beside the measured number, compound 4's estimate is 3.0-fold (0.48 log units) below it; measured number inside the range.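

In this assay, putting 5-methylthiophen-2-yl in place of thiophen-3-yl on the second core again gave a large drop, a 15-fold lower number from compound 3 to compound 4 (1.16 log units; beyond the scatter), so the direction carried over but the size did not: the same change on two cores in this assay, a 64-fold lower number (1.81 log units; beyond the scatter) from compound 2 to compound 1 and a 15-fold lower number (1.16 log units; beyond the scatter) from compound 3 to compound 4, 4.4-fold (0.64 log units) apart, beyond the scatter of two such steps. With 5-methylthiophen-2-yl in place, the double-bond configuration alone gave a 2.0-fold higher number from compound 1 to compound 4 (0.30 log units; within the scatter). These two pairs show that the change helped on both cores, but they do not give a size that could be relied on for a further core.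

Going by these compounds, it remains open how much of the drop comes from the methyl group and how much from the switch to thiophen-2-yl. An ethyl group or an amine in place of that methyl also remains untested in the compounds shown here.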